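One Methyl Added to Compound 2

The source may report more compounds than this note shows. Statements on the series, on what has been measured and on what is new or still open speak of the compounds shown alone.

Compound 1 `Cc1ccc(C(Br)C(Br)c2ncc([N+](=O)[O-])n2C)cc1`: 11200 nM
Compound 2 `Cn1c([N+](=O)[O-])cnc1/C=C/c1ccccc1`: > 100000 nM (a limit, not a number)

Both compounds were tested in an ADME assay on HeLa cells (Homo sapiens) for cytotoxicity, read by resazurin assay, with a stated time of 2 days; on this read-out lower numbers stand for stronger inhibition and higher numbers for weaker inhibition. Only compound 1 gave an actual number there. Compound 2 stands at the limit of > 100000 nM in this assay, at which 1 of the 2 values shown sits. Its true value is therefore unknown.

Compound 3 `Cc1ccccc1/C=C/c1ncc([N+](=O)[O-])n1C` differs from compound 2 in one place: methyl in place of hydrogen on an aromatic carbon. This is a methyl in place of hydrogen on an aromatic carbon, ortho to a large group. Going by the values given here, no measured pair here shows what such a change does in this assay, so the expectation rests mainly on compound 2. For compound 2, > 100000 nM is a limit. A small change is expected, with no step beyond the usual scatter and no clear direction, and the assay may well report only a limit again. The expected change is an at least 1.1-fold lower number from compound 2 to compound 3 (0.04 log units; that floor lies within the scatter). The estimate for compound 3 is 90000 nM, with an expected range from 30000 nM to 150000 nM.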

Compound 3, half-maximal inhibitory concentration: 93300 nM
For compound 3 the middle estimate is 1.0-fold (0.02 log units) below the measured one; the measured number falls inside the stated range.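

In this assay compound 3 gives a real number, so this methyl, on an aromatic carbon of a six-membered aromatic ring of carbon only and ortho to a large group, now has a measured reading rather than a limit. The change can be written only as a floor (an at least 1.0-fold lower number from compound 2 to compound 3 (0.03 log units; that floor lies within the scatter)), and a floor of that size does not by itself show that the methyl changes anything in this assay. The true size of the step stays unknown, since its starting point is not a number: the limit of > 100000 nM in this assay, at which 1 of the 3 values shown sits.

On these data alone, what an amine, a carboxylic acid or a longer chain would do in place of this methyl remains open, as does the result of putting the same methyl elsewhere on this aromatic ring. With a single step that starts from a limit, no trend can be drawn for this position, and nothing here can be carried over to other groups or to other parts of the shared core.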